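The source may hold more compounds than are shown below. What is called first, only, known or untested is meant among the compounds shown, and "the series" means these compounds.

Compound 1 `Nc1noc2c(N3CC[C@@H](NC(=O)c4ccc(-n5cnc(CCO)c5)cc4Cl)C3)ncc(Cl)c12` gives 0.005 in an ADME assay on a cell-free system (plasma, Homo sapiens), using equilibrium dialysis, with a stated time of 4 h, tested at 10 uM; on this read-out higher numbers stand for a larger free fraction and lower numbers for a smaller free fraction.
Compound 2 `Nc1noc2c(N3CC[C@@H](NC(=O)c4ccc(-n5cnc6ncccc65)cc4Cl)C3)ncc(Cl)c12` gives 0.008 in this assay.

Both numbers describe a small free fraction. Compound 2 holds the higher of the two numbers, yet the step of a 1.6-fold higher number from compound 1 to compound 2 (0.20 log units; within the scatter) is within the usual scatter, so the two compounds cannot be told apart on this read-out.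

Compound 3 `Cn1cc(-c2ccc(C(=O)N[C@@H]3CCN(c4ncc(Cl)c5c(N)noc45)C3)c(Cl)c2)cnc1=O` is the next compound, not yet measured. It differs from compound 2 in one place: a group of 8 heavy atoms (5 carbon, 2 nitrogen, 1 oxygen; one six-membered aromatic ring with 2 hetero atoms) in place of a group of 9 heavy atoms (6 carbon, 3 nitrogen; one five-membered aromatic ring with 2 hetero atoms, one six-membered aromatic ring with 1 hetero atom), on an aromatic carbon. Among the measured compounds shown here, the only measured step that bears on this change is the exchange at the same place on the way from compound 1 to compound 2, where a 1.6-fold higher number from compound 1 to compound 2 (0.20 log units; within the scatter) was seen. That earlier exchange of groups at this position left the free fraction essentially unchanged. The step of a 1.3-fold higher number from compound 2 to compound 3 (0.10 log units; within the scatter) is therefore expected to stay within the scatter as well, with no clear direction. For compound 3 the estimate in this assay is 0.01, with a range from 0.004 to 0.025.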

Compound 3, unbound fraction: 0.017
Estimate against measurement, compound 3: 1.7-fold (0.23 log units) below; the range from low to high includes it.
By their numbers in this assay, from the lowest: compounds 1 and 2 (each within the scatter of the next); then compound 3.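

The exchange at this aromatic carbon can shift the free fraction in this assay beyond the scatter, which the earlier exchange did not show: the six-membered aromatic ring with 2 hetero atoms gives a 2.1-fold higher number from compound 2 to compound 3 (0.33 log units; beyond the scatter) and also a 3.4-fold higher number from compound 1 to compound 3 (0.53 log units; beyond the scatter), both modest. The entering and leaving groups in the step to compound 3 have the same counts of hydrogen-bond donors and acceptors, so those counts do not separate compound 2 from compound 3. No measurement at hand explains the higher number of compound 3.

All three groups at this position are ring groups with no net charge. As far as these compounds go, how a carboxylic acid or an amine on a longer chain at this aromatic carbon would read in this assay remains open, as does whether the shift seen here would hold on a different core.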